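Phenyl in Place of Ethyl on the Sulfur

This account rests on a few compounds, and the source may have more. Where it says the series, first, only, none or still open, it means among the compounds named here.

Among the measured compounds shown here, compound 1 `CCSC(=S)SCC(=O)c1ccc(Cl)c(Cl)c1` sits second highest of the three numbers measured so far: in a functional assay on HeLa cells (Homo sapiens) for antiproliferative activity, read by resazurin assay (on this read-out lower numbers stand for stronger inhibition and higher numbers for weaker inhibition), compound 1 gives 7940 nM. For the measured compounds named here, compound 2 `CCSC(=S)SCC(=O)c1ccc(Cl)cc1` gives 5010 nM in this assay, and the only one-place step recorded, a 1.6-fold lower number from compound 1 to compound 2 (0.20 log units; within the scatter), comes from hydrogen in place of chloro on an aromatic carbon. Compound 3 `CCSC(=S)SCC(=O)c1ccc(CNC(=O)OCc2cccnc2)cc1` gives 20000 nM in this assay, a higher number than compound 1 and beyond the scatter, but no single change links the two.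

Compound 4 `O=C(CSC(=S)Sc1ccccc1)c1ccc(Cl)c(Cl)c1` differs from compound 1 by phenyl in place of ethyl on a sulfur. Going by the values given here, no measured step touches this sulfur, so nothing measured bears directly on the change; the one measured step lies elsewhere and stays within the scatter. Compound 4 is therefore expected to show a 1.0-fold higher number from compound 1 to compound 4 (0.00 log units; within the scatter) in this assay, with a wide range to reflect the lack of a guiding step. The estimate for compound 4 in this assay is 8000 nM, between 2500 nM and 25000 nM.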

Compound 4, half-maximal inhibitory concentration: 20000 nM
For compound 4 the middle estimate is 2.5-fold (0.40 log units) below the measured one, and the stated range covers the measured number.
By their numbers in this assay, from the lowest: compounds 2 and 1 (each within the scatter of the next); then compounds 3 and 4 (each within the scatter of the next).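

Among the compounds shown here, the sulfur that carries the ethyl group in compound 1 is the first place in these compounds where a one-place change goes beyond the scatter in this assay: phenyl in place of ethyl gives a 2.5-fold higher number from compound 1 to compound 4 (0.40 log units; beyond the scatter), a modest step. The earlier step, hydrogen in place of chloro on an aromatic carbon, stayed within the scatter, so this sulfur is the only position shown so far where the number responds to the group placed there. No measured evidence is at hand that explains this shift.

Ethyl and phenyl are the only groups shown on this sulfur, so it remains open whether the higher number belongs to the aromatic ring itself or would also appear with a benzyl group, a longer chain such as butyl, or a phenyl carrying an amine. On these data alone, it also remains open whether the same change would give a similar step on the core of compound 2.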